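This account rests on a few compounds, and the source may have more. Where it says the series, first, only, none or still open, it means among the compounds named here.

Compound 3 `Cc1c(C(=O)N/N=C\c2ccccc2)oc2cccc(O)c12` gives 29200 nM in a functional assay on PC-3 cells (Homo sapiens) for inhibition (on this read-out lower numbers stand for stronger inhibition and higher numbers for weaker inhibition), the highest of the three numbers in hand, though within the usual scatter of compound 1 `Cc1c(C(=O)N/N=C\c2c(O)cccc2Cl)oc2cccc(O)c12` with 18700 nM and of compound 2 `Cc1c(C(=O)N/N=C\c2cc([N+](=O)[O-])ccc2O)oc2cccc(O)c12` with 17100 nM. Compound 4 `Cc1c(C(=O)N/N=C\c2cc(Cl)ccc2O)oc2cccc(O)c12` differs from compound 3 in one place: 5-chloro-2-hydroxyphenyl in place of phenyl on a carbon with a double bond to nitrogen. Within the data shown here, one measured step bears on this change: a 1.6-fold higher number from compound 1 to compound 3 (0.19 log units; within the scatter), a swap between a substituted ring and plain phenyl that stayed within the scatter. Compound 2, whose ring also carries a hydroxy group, sits close to compound 1. Because a 1.6-fold higher number from compound 1 to compound 3 (0.19 log units; within the scatter) was small, the reverse kind of move is expected to give at most a slight shift to a lower number, a 1.7-fold lower number from compound 3 to compound 4 (0.23 log units; within the scatter). Compound 4 is therefore estimated at 17000 nM, with a range from 8000 nM to 36000 nM.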

Compound 4, half-maximal inhibitory concentration: 3120 nM
Compound 4: middle estimate off by 5.4-fold (0.74 log units), on the high side; the measured number lies below the stated range.
By their numbers in this assay, from the lowest: compound 4; then compounds 2, 1 and 3 (each within the scatter of the next).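

In this assay, among these compounds, the substituted ring on the carbon with a double bond to nitrogen now clearly matters: a 9.4-fold lower number from compound 3 to compound 4 (0.97 log units; beyond the scatter) is the first step here beyond the scatter. The arrangement of the ring's groups also counts, as 5-chloro-2-hydroxyphenyl in place of 2-chloro-6-hydroxyphenyl gives a 6.0-fold lower number from compound 1 to compound 4 (0.78 log units; beyond the scatter) with the same two groups on the ring. Chloro in place of nitro gives a 5.5-fold lower number from compound 2 to compound 4 (0.74 log units; beyond the scatter) as a further gain.

No measurement shown explains these differences. From the compounds shown here alone, whether bromo or methoxy in place of chloro would keep this lower number remains open.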